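Cinnamate glycolamide anilides: outlook for a thiazolyl amide

A few compounds are considered here, and "the series" means these few. Any claim that something is new, unique, unknown or untested is made for them only; others in the source may bear on it.

Measured so far in a functional assay on PC-3 cells (Homo sapiens) for cytotoxicity, read by MTT assay, with a stated time of 72 h; on this read-out lower numbers stand for stronger inhibition and higher numbers for weaker inhibition:
- compound 1 `COCOc1cc(/C=C/C(=O)OCC(=O)Nc2ccc(OC)cc2)ccc1OCc1ccccc1`, > 200000 nM
- compound 2 `COc1ccc(NC(=O)COC(=O)/C=C/c2ccc(OCc3ccccc3)c(O)c2)cc1`, > 200000 nM

Compound 1 gives only a limit in this assay, > 200000 nM, so no number stands for it. Compound 2 likewise gives only a limit in this assay, > 200000 nM. The step that the two limits leave unreadable from compound 1 to compound 2 is therefore not readable, and its change, hydrogen in place of methoxymethyl on an oxygen on an aromatic ring, cannot be sized. Both values rest on the same fact, namely (the limit of > 200000 nM in this assay, at which 2 of the 2 values shown sit).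

Compound 3 `COCOc1cc(/C=C/C(=O)OCC(=O)Nc2nccs2)ccc1OCc1ccccc1` differs from compound 1 by 1,3-thiazol-2-yl in place of 4-methoxyphenyl on an amide-type nitrogen. Among the measured compounds shown here, no measured step touches the amide-type nitrogen, and the one step recorded is itself unreadable, so nothing in this assay gives a size or direction for this change. The expectation for compound 3 rests only on the limit seen for compound 1 and stays near that limit, with a wide range that allows some activity to appear.

Compound 3 is estimated at 150000 nM, between 20000 nM and 400000 nM. This estimate implies an expected step of an at least 1.3-fold lower number from compound 1 to compound 3 (0.12 log units; that floor lies within the scatter).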

Compound 3, half-maximal inhibitory concentration: > 200000 nM
Compound 3: only a limit was reported; the forecaster's own chance of this, stated with the estimate: 65%; middle value at least 1.3-fold (0.12 log units) away from the limit.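

No step can be read between compound 1 and compound 3, as both give only a limit: the limit of > 200000 nM in this assay, at which 3 of the 3 values shown sit.

The compounds shown leave open whether any group on the amide-type nitrogen, or any other change to the shared core, would give a measurable value in this assay.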